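This account rests on a few compounds, and the source may have more. Where it says the series, first, only, none or still open, it means among the compounds named here.

Measured compounds:
compound 1 `COc1ccc2c(=O)c(/C=C/C(=O)Nc3cccc(Cl)c3)coc2c1`: > 100000 nM
compound 2 `COc1ccc2c(=O)c(/C=C/C(=O)Nc3ccccc3OC)coc2c1`: 32300 nM
compound 3 `COc1ccc2c(=O)c(/C=C/C(=O)NCc3ccc(C)cc3)coc2c1`: 14300 nM

All three share the same core and differ only in the group on the amide-type nitrogen. In a functional assay on Huh-7 cells (Homo sapiens) for inhibition, read by MTT assay, with a stated time of 48 h (on this read-out higher numbers stand for weaker inhibition and lower numbers for stronger inhibition), compound 1 reaches only the limit of the assay, > 100000 nM, so no number is known for it; it stands at the limit of > 100000 nM in this assay, at which 1 of the 3 values shown sits, and is therefore the weakest inhibitor of the set on this read-out. Compound 2 gives 32300 nM in this assay, and compound 3 gives 14300 nM. The two measured steps from compound 1, an at least 3.0-fold lower number from compound 1 to compound 2 (0.49 log units; beyond the scatter) and an at least 6.9-fold lower number from compound 1 to compound 3 (0.84 log units; beyond the scatter), both move away from the limit; between compound 2 and compound 3 the step is a 2.3-fold lower number from compound 2 to compound 3 (0.35 log units; beyond the scatter).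

Compound 4 `COc1ccc2c(=O)c(/C=C/C(=O)Nc3ccc(F)cc3)coc2c1` is not yet measured. The change from compound 1 is 4-fluorophenyl in place of 3-chlorophenyl on an amide-type nitrogen. Going by the values given here, no measured step exchanges one halogen-bearing phenyl for another, so the two steps from compound 1 give only a loose guide: both leave the limit, but only by a moderate amount, and compound 4 keeps an aryl group of the same size. Compound 4 is therefore expected to stay near the limit, with a step of an at least 1.4-fold lower number from compound 1 to compound 4 (0.15 log units; that floor lies within the scatter) of no certain direction beyond the scatter. The estimate for compound 4 is 70000 nM, within 20000 nM to 200000 nM.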

Compound 4, half-maximal inhibitory concentration: 33900 nM
Compound 4: the middle estimate sits 2.1-fold (0.31 log units) above what was measured; the range from low to high includes it.
By their numbers in this assay, from the lowest: compound 3; then compounds 2 and 4 (each within the scatter of the next). At a limit, above all of these: compound 1.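

In this assay, the exchange of 3-chlorophenyl for 4-fluorophenyl on the amide-type nitrogen gives an at least 2.9-fold lower number from compound 1 to compound 4 (0.46 log units; beyond the scatter), so a halogen-bearing phenyl there need not leave a compound at the limit. Compound 2 and compound 4, both with a substituted phenyl on that nitrogen, cannot be told apart, with a 1.0-fold higher number from compound 2 to compound 4 (0.02 log units; within the scatter), while the 4-methylbenzyl group stays ahead of 4-fluorophenyl, with a 2.4-fold higher number from compound 3 to compound 4 (0.37 log units; beyond the scatter). Compound 1 alone gives a limit and not a number: the limit of > 100000 nM in this assay, at which 1 of the 4 values shown sits.

The compounds shown leave open whether the halogen or its place separates compound 1 from compound 4, as the two change together in this single step. They also leave open how 4-chlorophenyl, or an amine, a carboxylic acid or a longer chain on the amide-type nitrogen, would read in this assay.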